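The source may report more compounds than this note shows. Statements on the series, on what has been measured and on what is new or still open speak of the compounds shown alone.

In an ADME assay on BJ cells (Homo sapiens) for cytotoxicity, with a stated time of 72 h (a higher number here means that more compound is needed for the effect, a lower number that less compound is needed), compound 1 (`O=C(Nc1cccc(-c2nc3ccccc3s2)c1)c1cc([N+](=O)[O-])c(O)cc1Cl`) gives > 25000 nM as a limit of the assay and not a number. Compound 2 (`O=C(Nc1ccc(F)c(-c2nc3ccccc3s2)c1)c1cc([N+](=O)[O-])ccc1Cl`) gives > 25000 nM and this too is a limit. Compound 3 (`O=C(Nc1ccc(O)c(-c2nc3ccccc3s2)c1)c1cc([N+](=O)[O-])ccc1Cl`) gives > 25000 nM as a limit as well, so it has no number of its own. The series rests on the limit of > 25000 nM in this assay, at which 3 of the 3 values shown sit, and shows no order among its members. Compound 4 (`O=C(Nc1cccc(-c2nc3ccccc3s2)c1)c1cc([N+](=O)[O-])ccc1Cl`) carries hydrogen in place of hydroxy on an aromatic carbon ortho to a 1,3-benzothiazol-2-yl group (hydrogen in place of hydroxy on an aromatic carbon) and is still to be measured. Going by the values given here, the one measured step that bears on this change is a step that the two limits leave unreadable from compound 2 to compound 3 and it offers no size to carry over. In this assay no step beyond the scatter is therefore expected, in either direction. Among the compounds with values here, the estimated step that the limit leaves unreadable from compound 3 to compound 4 is expected to stay within the usual scatter because the limit of > 25000 nM in this assay, at which 3 of the 3 values shown sit, holds for every compound measured so far. For compound 4 the estimate is 30000 nM with an expected range from 15000 nM to 50000 nM and the assay will most likely report only a limit.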

Compound 4, half-maximal effective concentration: > 27000 nM
Compound 4: a limit, no number; the forecaster's own chance of this, stated with the estimate: 85%; the middle value lies beyond the limit too.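

In this assay compound 4 gives > 27000 nM, a limit of the assay and not a number, so its steps from compound 1, compound 2 and compound 3 cannot be read. The compounds shown leave open what number any of them would reach in this assay, and whether hydroxy, fluoro or hydrogen at the one place where compound 2, compound 3 and compound 4 differ changes it.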